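This account rests on a few compounds, and the source may have more. Where it says the series, first, only, none or still open, it means among the compounds named here.

In a functional assay on MCF7 cells (Homo sapiens) for cytotoxicity, read by sulforhodamine B assay, with a stated time of 24 h (on this read-out higher numbers stand for weaker inhibition and lower numbers for stronger inhibition), compound 1 (`N=c1oc2ccccc2cc1C(=O)N/N=C1\C(=O)Nc2ccc(S(=O)(=O)N3CCOCC3)cc21`) gives 20800 nM and compound 3 (`Cc1ccc(S(=O)(=O)N/N=C2\C(=O)Nc3ccc(S(=O)(=O)N4CCOCC4)cc32)cc1`) gives 38400 nM on the same read-out, while compound 2 (`Cc1ccc(/N=C2\C(=O)Nc3ccc(S(=O)(=O)N4CCOCC4)cc32)cc1`) gives 55900 nM there. Compound 2 lies within the scatter of compound 3 and beyond the scatter above compound 1. Compound 4 (`CC(=O)c1cccc(/N=C2\C(=O)Nc3ccc(S(=O)(=O)N4CCOCC4)cc32)c1`) carries 3-acetylphenyl in place of 4-methylphenyl on a double-bonded nitrogen and otherwise matches compound 2. Going by the values given here, no two measured compounds differ in one place alone, so no measured step speaks directly to this change. All three share the core and differ in what they carry, and their values reach only from compound 1 at 20800 nM to compound 2 at 55900 nM in this small set. On that basis, no step beyond the scatter is expected in this assay for the new group. The estimated 1.3-fold lower number from compound 2 to compound 4 (0.12 log units; within the scatter) stays within the scatter. For compound 4 the expected value is 42000 nM with an estimated range from 20000 nM to 85000 nM on this read-out.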

Compound 4, half-maximal inhibitory concentration: 39200 nM
Estimate against measurement, compound 4: 1.1-fold (0.03 log units) above; low and high end bracket the measured number.
By their numbers in this assay, from the lowest: compounds 1, 3, 4 and 2 (each within the scatter of the next, the first and the last beyond it).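

In this assay, going by these compounds alone, 3-acetylphenyl in place of 4-methylphenyl on a double-bonded nitrogen gives a 1.4-fold lower number from compound 2 to compound 4 (0.15 log units; within the scatter), the first step at this position that can be read at all. This position therefore takes an aromatic ring with an added carbonyl and a hydrogen-bond acceptor, which 4-methylphenyl lacks, without any difference that this read-out can separate from the scatter. No measurement is at hand that would explain why the two compounds read alike.

The compounds shown leave open whether an amine or a carboxylic acid in place of the acetyl group on this ring would give a step beyond the scatter. Within the data shown here, they also leave open whether a single step at this position can move the number at all, since this one step is the only evidence.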